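Swapping chloro for fluoro on the aromatic ring of compound 1

The source may hold more compounds than are shown below. What is called first, only, known or untested is meant among the compounds shown, and "the series" means these compounds.

Compound 1, `Cc1nn(C)c2c1C(c1cccc(Cl)c1)=NCCN2`: 0.63 mg/kg
Compound 2, `CCN1CCN=C(c2cccc(Cl)c2)c2c(C)nn(C)c21`: 0.63 mg/kg
Compound 3, `Cc1nn(C)c2c1C(c1cccc(Cl)c1)=NCCN2N=O`: 1.25 mg/kg

In a functional assay on the whole organism for positive allosteric modulation, with Rattus norvegicus as the target (on this read-out lower numbers stand for an effect already at smaller amounts and higher numbers for an effect only at larger amounts of compound), compound 1 gives 0.63 mg/kg. It stands level with compound 2 at the digits shown, the two together giving the lowest numbers of the three, while compound 3 lies higher by a gap still within the scatter: a 2.0-fold higher number from compound 1 to compound 3 (0.30 log units; within the scatter).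

Compound 4, `Cc1nn(C)c2c1C(c1cccc(F)c1)=NCCN2`, has not yet been measured. It differs from compound 1 as follows: fluoro in place of chloro on an aromatic carbon.

Within the data shown here, none of the measured steps touches this part of the molecule. The steps from compound 1 to compound 2 (no change at the digits printed from compound 1 to compound 2 (within the scatter)) and from compound 2 to compound 3 (a 2.0-fold higher number from compound 2 to compound 3 (0.30 log units; within the scatter)) alter only the nitrogen on an aromatic ring in a ring, and all of them stay within the scatter. There is therefore no direct guide to the effect of fluoro in place of chloro on the aromatic carbon.

With nothing in the data pointing to a large shift, compound 4 is expected to land close to compound 1, perhaps slightly higher, as an estimated step of a 2.0-fold higher number from compound 1 to compound 4 (0.30 log units; within the scatter). The estimate for compound 4 is 1.25 mg/kg, with a range from 0.4 mg/kg to 4 mg/kg.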

Compound 4, minimum effective dose: 2.5 mg/kg
Estimate against measurement, compound 4: 2.0-fold (0.30 log units) below, within the range that was stated.
By their numbers in this assay, from the lowest: compounds 1, 2, 3 and 4 (each within the scatter of the next, the first and the last beyond it).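

In this assay, fluoro in place of chloro gives a 4.0-fold higher number from compound 1 to compound 4 (0.60 log units; beyond the scatter) and is the only step shown here that lies beyond the scatter. A change of one atom on this aromatic carbon, meta to a large group, therefore moves the read-out more clearly than the earlier changes on the ring nitrogen, and chloro is the better of the two halogens tested here. No supporting data explain the rise in the required dose.

As far as these compounds go, it remains open how bromo, methyl or methoxy on this carbon, or a plain hydrogen in place of the halogen, would compare with chloro. From the compounds shown here alone, it is also open whether the same swap would have a similar effect on compound 2, which carries ethyl on the ring nitrogen.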